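Swapping phenyl for neopentyl on two related cores

This account rests on a few compounds, and the source may have more. Where it says the series, first, only, none or still open, it means among the compounds named here.

Of the compounds shown here, three have been measured in an ADME assay on Caco-2 cells (Homo sapiens) for permeability, read by LC-MS, in the apical to basolateral direction, with a stated time of 60 min, at pH 6.5; on this read-out higher numbers stand for higher permeability and lower numbers for lower permeability. Compound 1 `O=C([C@H](O)c1ccccc1)N1CC[C@@H]2C[C@@]21C(=O)NCc1cc(Cl)ccc1-n1cnnn1` gives 2.6 10^-6 cm/s, the lowest of the three. Compound 2 `O=C(NCc1cc(Cl)ccc1-n1cnnn1)[C@@H]1[C@H]2C[C@H]2CN1C(=O)[C@H](O)c1ccccc1` gives 12 10^-6 cm/s; how its core differs from the core of compound 1 is not broken down here. Compound 3 `CC(C)(C)C[C@@H](O)C(=O)N1C[C@@H]2C[C@@H]2[C@H]1C(=O)NCc1cc(Cl)ccc1-n1cnnn1` gives 25 10^-6 cm/s. Compound 3 differs from compound 2 in one place, (neopentyl in place of phenyl on a saturated chain carbon bound to a carbonyl carbon and an oxygen on a saturated carbon), and this change brought a 2.1-fold higher number from compound 2 to compound 3 (0.32 log units; beyond the scatter). Compound 4 `CC(C)(C)C[C@@H](O)C(=O)N1CC[C@@H]2C[C@@]21C(=O)NCc1cc(Cl)ccc1-n1cnnn1` is not yet measured; it differs from compound 1 by the same change, (neopentyl in place of phenyl on a saturated chain carbon bound to a carbonyl carbon and an oxygen on a saturated carbon), made on the core of compound 1 rather than on the core of compound 2. Because the measured change gave a 2.1-fold higher number from compound 2 to compound 3 (0.32 log units; beyond the scatter), a step of similar size is expected for compound 4, namely a 2.1-fold higher number from compound 1 to compound 4 (0.33 log units; beyond the scatter). Compound 4 is therefore estimated at 5.5 10^-6 cm/s, with a likely range from 2.5 10^-6 cm/s to 12 10^-6 cm/s.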

Compound 4, apparent permeability: 7.8 10^-6 cm/s
The estimate for compound 4 lay 1.4-fold (0.15 log units) below the measured number; low and high end bracket the measured number.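

Neopentyl in place of phenyl gave a 3.0-fold higher number from compound 1 to compound 4 (0.48 log units; beyond the scatter) in this assay. The change carried over from one core to the other, in direction and in size: the same change on two cores in this assay, a 2.1-fold higher number (0.32 log units; beyond the scatter) from compound 2 to compound 3 and a 3.0-fold higher number (0.48 log units; beyond the scatter) from compound 1 to compound 4, 1.4-fold (0.16 log units) apart, within the scatter of two such steps

Within the data shown here, this agreement rests on only two pairs of compounds, so it supports carrying the change between these two cores but sets no rule for other cores, and it does not explain why the number goes up. The compounds shown leave open whether a different group on the same saturated chain carbon, such as an amine, a carboxylic acid or a longer chain, would give a similar step. As far as these compounds go, how the neopentyl change behaves on a third core also remains open.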